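Fluoro for methoxy on the amide side: an expectation

The source may report more compounds than this note shows. Statements on the series, on what has been measured and on what is new or still open speak of the compounds shown alone.

Of the compounds shown here, three built on a shared core have been tested in a functional assay on L02 cells (Homo sapiens) for inhibition, read by MTT assay, with a stated time of 48 h; a higher number here means a weaker inhibitor, a lower number a stronger inhibitor. Compound 1 `COc1ccc2c(=O)c(/C=C/C(=O)Nc3cccc(Cl)c3)coc2c1` reaches only the limit of the measurement, > 200000 nM. Compound 3 `COc1ccc2c(=O)c(/C=C/C(=O)Nc3ccccc3)coc2c1` likewise gives a limit, > 200000 nM. Compound 2 `COc1ccc(CNC(=O)/C=C/c2coc3cc(O)ccc3c2=O)cc1` also stops at a limit, > 200000 nM. Compound 2 therefore stands at the same limit as the other two, and no number separates any of them. The change from compound 2 to compound 4 `O=C(/C=C/c1coc2cc(O)ccc2c1=O)NCc1ccc(F)cc1` is fluoro in place of methoxy on an aromatic carbon. Going by the values given here, the only single-site step among the measured compounds, a step that the two limits leave unreadable from compound 1 to compound 3, cannot be read because the limit of > 200000 nM in this assay, at which 3 of the 3 values shown sit, holds both of its ends. That step bears on the new change only in showing that a small exchange on an aromatic carbon left the result at the limit. For compound 4 the step that the limit leaves unreadable from compound 2 to compound 4 is therefore expected to be no more than a move from one limit to another, with no direction readable. Compound 4 is estimated at 300000 nM, between 150000 nM and 1000000 nM, and is most likely to be reported again only as a limit in this assay.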

Compound 4, half-maximal inhibitory concentration: > 200000 nM
Compound 4 gave a limit, no number; the forecaster's own chance of this, stated with the estimate: 85%; the middle value does not contradict the limit.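

The step from compound 2 to compound 4, fluoro in place of methoxy, cannot be read, since both compounds give only a limit: the limit of > 200000 nM in this assay, at which 4 of the 4 values shown sit.

The compounds shown leave open which change to this structure, if any, would give an actual number in this assay.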